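A Difluorophenyl Replaced by (Ethoxycarbonyl)methyl: Cell Tolerance

A few compounds are considered here, and "the series" means these few. Any claim that something is new, unique, unknown or untested is made for them only; others in the source may bear on it.

Compound 1 `Cc1ccccc1-c1nn(-c2cc(F)ccc2F)cc1CNCCN1CCN(C)CC1` has been tested in an ADME assay on Huh-7 cells (Homo sapiens) for cytotoxicity; a higher number here means that more compound is tolerated, a lower number that less compound is tolerated. In this assay compound 1 gives > 20000 nM, which is a limit of the assay rather than a measured number. Compound 2 `Cc1ccccc1-c1nn(-c2ccc(F)cc2F)cc1CNCCCCO`, built on the same core, has also been tested in this assay. There compound 2 gives > 20000 nM, again a limit and not a number. Compound 1 thus sits at the limit of > 20000 nM in this assay, at which 2 of the 2 values shown sit, so the two compounds cannot be told apart on these figures. Compound 3 `CCOC(=O)Cn1cc(CNCCN2CCN(C)CC2)c(-c2ccccc2C)n1` has not yet been tested. It differs from compound 1 by (ethoxycarbonyl)methyl in place of 2,5-difluorophenyl on an aromatic nitrogen. Within the data shown here, no measured pair shows what such a change does here, so the step from compound 1 to compound 3 in this assay is expected to remain within the scatter, as a step that the limit leaves unreadable from compound 1 to compound 3. On this basis compound 3 is expected to give about 25000 nM in this assay, most likely between 8000 nM and 80000 nM.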

Compound 3, half-maximal cytotoxic concentration: > 20000 nM
Compound 3: only a limit was reported; the forecaster's own chance of this, stated with the estimate: 75%; the middle value does not contradict the limit.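

Compound 1 and compound 3 both sit at a limit rather than at a number, so no step between them can be read: the limit of > 20000 nM in this assay, at which 3 of the 3 values shown sit.

The compounds shown leave open how much of either compound the cells tolerate, and whether (ethoxycarbonyl)methyl in place of 2,5-difluorophenyl changes that at all.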